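The source may report more compounds than this note shows. Statements on the series, on what has been measured and on what is new or still open speak of the compounds shown alone.

Compound 1 `O=C(Nc1ccc(I)cc1)Nc1nc(-c2cc3ccccc3o2)cs1` is the reference point for this set. Among the measured compounds shown here, in a physicochemical assay, with a stated time of 6 min (a lower number here means a stronger inhibitor, a higher number a weaker inhibitor), compound 1 gives 62000 nM, the lowest of the three numbers measured so far. Compound 3 `O=C(Nc1ccc(I)cc1)Nc1nc(-c2cc3cc([N+](=O)[O-])ccc3o2)cs1` gives 62400 nM, and the step of a 1.0-fold higher number from compound 1 to compound 3 (0.00 log units; within the scatter) does not register. For the measured compounds named here, compound 2 `O=C(Nc1ccccc1)Nc1nc(-c2cc3cc([N+](=O)[O-])ccc3o2)cs1` gives 183000 nM; the step of a 2.9-fold lower number from compound 2 to compound 3 (0.47 log units; beyond the scatter) is the only change in this set that moved the read-out past the scatter.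

Compound 4 `O=C(Nc1cccc(F)c1)Nc1nc(-c2cc3ccccc3o2)cs1` has not yet been measured. It differs from compound 1 in one place: 3-fluorophenyl in place of 4-iodophenyl on an amide-type nitrogen. Going by the values given here, the measured step that bears on this is a 2.9-fold lower number from compound 2 to compound 3 (0.47 log units; beyond the scatter), where iodo in place of hydrogen on an aromatic carbon lowered the number modestly; compound 4 gives up that iodo, and the 3-fluorophenyl that enters has no measured counterpart in this set. The expected direction is therefore a modestly higher number in this assay, roughly the iodo step run backwards, with wide uncertainty on the fluoro side. Compound 4 is expected to give 150000 nM in this assay, within 60000 nM to 400000 nM. The estimated step of a 2.4-fold higher number from compound 1 to compound 4 (0.38 log units; beyond the scatter) is expected to be of modest size.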

Compound 4, half-maximal inhibitory concentration: 4520 nM
The estimate for compound 4 lay 33-fold (1.52 log units) above the measured number, outside the stated range (below it).
By their numbers in this assay, from the lowest: compound 4; then compounds 1 and 3 (each within the scatter of the next); then compound 2.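

In this assay, among the compounds shown here, the group on the amide-type nitrogen turns out to be a far more sensitive place than the earlier compounds suggested: 3-fluorophenyl in place of 4-iodophenyl gives a 14-fold lower number from compound 1 to compound 4 (1.14 log units; beyond the scatter), well beyond anything else seen. For the compounds shown here, the only earlier change on this aryl group, iodo in place of hydrogen on an aromatic carbon, gave a 2.9-fold lower number from compound 2 to compound 3 (0.47 log units; beyond the scatter) on the nitro-bearing core, so that modest gain does not mean 4-iodophenyl is a favourable group here, and an aryl group without iodine can give a much lower number. Nothing available accounts for the size of this step.

As far as these compounds go, this single step changes both the halogen and its numbered place on the ring, so it remains open whether the lower number follows the fluoro group, the loss of iodo or the change of place. Also open, from the compounds shown here alone, are how the number responds to other groups on this phenyl, such as methoxy, an amine or a carboxylic acid, and whether 3-fluorophenyl has a similar effect on the core of compound 3.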